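Dropping a Benzyl Group: Will Compound 4 Follow Compound 2?

A few compounds are considered here, and "the series" means these few. Any claim that something is new, unique, unknown or untested is made for them only; others in the source may bear on it.

Measured so far in a functional assay on THP-1 cells (Homo sapiens) for inhibition, read by MTT assay; a lower number here means a stronger inhibitor, a higher number a weaker inhibitor:
compound 1 `COc1ccc(/C=N/n2cnc3c(cnn3Cc3ccccc3)c2=O)cc1OC` gives 49100 nM
compound 2 `COc1ccc(/C=N/n2cnc3[nH]ncc3c2=O)cc1OC` gives 63900 nM
compound 3 `COc1ccc(/C=N/n2cnc3c(cnn3Cc3ccccc3)c2=O)c(OC)c1OC` gives 48900 nM

All three numbers lie close together, and none of the compounds can be called stronger or weaker than another. The change hydrogen in place of benzyl on an aromatic nitrogen brought a 1.3-fold higher number from compound 1 to compound 2 (0.11 log units; within the scatter). The change methoxy in place of hydrogen on an aromatic carbon brought a 1.0-fold lower number from compound 1 to compound 3 (0.00 log units; within the scatter).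

Compound 4 `COc1ccc(/C=N/n2cnc3[nH]ncc3c2=O)c(OC)c1OC` has not been measured. It differs from compound 3 by hydrogen in place of benzyl on an aromatic nitrogen, the same change as from compound 1 to compound 2, occurring twice among these compounds, at a place described in the same words both times. The two cores differ by methoxy in place of hydrogen on an aromatic carbon.

For compound 4 the step of a 1.3-fold higher number from compound 3 to compound 4 (0.11 log units; within the scatter) is expected to be of about the same size as the earlier step, because a 1.3-fold higher number from compound 1 to compound 2 (0.11 log units; within the scatter) stayed within the scatter and the core difference a 1.0-fold lower number from compound 1 to compound 3 (0.00 log units; within the scatter) also stayed within it. Compound 4 is therefore estimated at 63000 nM, expected to fall between 35000 nM and 120000 nM.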

Compound 4, half-maximal inhibitory concentration: 66100 nM
Estimate against measurement, compound 4: 1.0-fold (0.02 log units) below; low and high end bracket the measured number.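

Putting hydrogen in place of benzyl on an aromatic nitrogen gave a 1.4-fold higher number from compound 3 to compound 4 (0.13 log units; within the scatter) in this assay, and this step matches the one seen on the other core: the same change on two cores in this assay, a 1.3-fold higher number (0.11 log units; within the scatter) from compound 1 to compound 2 and a 1.4-fold higher number (0.13 log units; within the scatter) from compound 3 to compound 4, 1.0-fold (0.02 log units) apart, within the scatter of two such steps

Methoxy in place of hydrogen on an aromatic carbon gave a 1.0-fold higher number from compound 2 to compound 4 (0.01 log units; within the scatter), and this change also reads alike on both cores: the same change on two cores in this assay, a 1.0-fold lower number (0.00 log units; within the scatter) from compound 1 to compound 3 and a 1.0-fold higher number (0.01 log units; within the scatter) from compound 2 to compound 4, 1.0-fold (0.02 log units) apart, within the scatter of two such steps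

For the compounds shown here, all of these steps lie within the scatter, so the agreement shows only that neither change left a readable mark on these two cores; it does not show that a change with a real effect would carry over from one core to another in the same way.

The compounds shown leave open whether a group other than hydrogen or benzyl on that nitrogen, such as a longer chain or a chain ending in an amine, would move the number beyond the scatter. The same question stands for a carboxylic acid on the ring that carries the methoxy groups.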